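A few compounds are considered here, and "the series" means these few. Any claim that something is new, unique, unknown or untested is made for them only; others in the source may bear on it.

Among the compounds with values here, in a functional assay on HOS cells (Homo sapiens) for inhibition, read by CCK-8 assay, with a stated time of 72 h, tested at 1 uM (a higher number here means more inhibition at the concentration tested (going by the name of the read-out), a lower number less inhibition), compound 1 `COc1ccc(OC)c(N2C(=O)CSC2c2cccc(C(=O)NCCCCc3ccccc3)c2)c1` gives 5%, the lowest of the three numbers measured so far. Compound 3 `O=C(NCCCCc1ccccc1)c1cccc(C2SCC(=O)N2c2ccccc2)c1` gives 55%, and compound 2 `O=C(NCCCCc1ccccc1)c1cccc(C2SCC(=O)N2c2cccc(F)c2)c1` gives 84%. The two measured steps that start from compound 1 are both large: a number 50 percentage points higher from compound 1 to compound 3 (beyond the scatter) and a number 79 percentage points higher from compound 1 to compound 2 (beyond the scatter). Between the two compounds that carry a simple or a fluorinated phenyl ring the step is smaller but still beyond the scatter: a number 29 percentage points lower from compound 2 to compound 3 (beyond the scatter).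

Compound 4 `O=C(NCCCCc1ccccc1)c1cccc(C2SCC(=O)N2c2ccccc2F)c1` has not yet been measured in this assay. It differs from compound 1 in a single place: 2-fluorophenyl in place of 2,5-dimethoxyphenyl on an amide-type nitrogen in a ring. The two measured steps from compound 1 both remove the same 2,5-dimethoxyphenyl group and replace it with a phenyl ring, with or without a fluorine, and both brought large gains in inhibition. Compound 4 makes the same kind of exchange, keeping one fluorine as compound 2 does, though as 2-fluorophenyl rather than 3-fluorophenyl. A large rise is therefore expected for compound 4, with its size estimated to lie somewhere between the two known steps that start from compound 1: a number 60 percentage points higher from compound 1 to compound 4 (beyond the scatter). Compound 4 is estimated to give 65% in this assay, with a range from 40% to 90%.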

Compound 4, a percentage reported as inhibition, at one concentration (the size of the read-out at that concentration, not a potency): 83%
Compound 4: middle estimate off by 18 percentage points, on the low side; the measured number falls inside the stated range.
By their numbers in this assay, from the lowest: compound 1; then compound 3; then compounds 4 and 2 (each within the scatter of the next).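

Read in this assay, the new result shows that the gain on leaving the 2,5-dimethoxyphenyl group does not depend on fluorine sitting in one particular place on the ring: the exchange for 2-fluorophenyl gives a number 78 percentage points higher from compound 1 to compound 4 (beyond the scatter). Adding the fluorine to the plain phenyl ring of compound 3 also counts for something at this second place, with a number 28 percentage points higher from compound 3 to compound 4 (beyond the scatter), and moving it makes no difference that can be told apart, with a number 1 percentage points lower from compound 2 to compound 4 (within the scatter). Nothing available on the compounds accounts for these differences, so the data record what happens at this ring nitrogen without explaining it.

The compounds shown leave open whether another atom on the same phenyl ring, such as chlorine, or a small group such as methyl, would match fluorine here. They also leave open whether a phenyl ring with a single methoxy group would stay high like compound 3 or fall toward compound 1, and whether compound 2 and compound 4 would still match at other concentrations.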